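Aryl Exchange at the Aromatic Nitrogen of a Weak Series

A few compounds are considered here, and "the series" means these few. Any claim that something is new, unique, unknown or untested is made for them only; others in the source may bear on it.

Compound 1 `Cc1ccc(-n2cc(CSC(=S)N3CCN(C(=O)OC(C)(C)C)CC3)nn2)cc1`: 114000 nM
Compound 2 `CC(C)(C)OC(=O)N1CCN(C(=S)SCc2cn(Cc3ccc(Cl)c(Cl)c3)nn2)CC1`: > 128000 nM

In a functional assay on ECa-109 cells (Homo sapiens) for inhibition, read by MTT assay, with a stated time of 72 h (a lower number here means a stronger inhibitor, a higher number a weaker inhibitor), compound 1 gives 114000 nM. For compound 2 the result is only a limit of the assay, > 128000 nM. Compound 2 thus stands at the weak end of what has been measured, with a bound rather than a number; (the limit of > 128000 nM in this assay, at which 1 of the 2 values shown sits). Going by the values given here, the one measured step, an at least 1.1-fold higher number from compound 1 to compound 2 (0.05 log units; that floor lies within the scatter), is itself a floor within the scatter and gives no direction to lean on.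

Compound 3 `COc1ccc(Cn2cc(CSC(=S)N3CCN(C(=O)OC(C)(C)C)CC3)nn2)cc1` is reached from compound 2 by 4-methoxyphenyl in place of 3,4-dichlorophenyl on a saturated chain carbon bound to an aromatic nitrogen. Because an at least 1.1-fold higher number from compound 1 to compound 2 (0.05 log units; that floor lies within the scatter) lies within the scatter, no movement beyond the scatter is expected in this assay either. Compound 3 is therefore expected to show an at least 1.0-fold lower number from compound 2 to compound 3 (0.02 log units; that floor lies within the scatter). Compound 3 is estimated at 120000 nM in this assay, between 60000 nM and 250000 nM, with a fair chance that only a limit is reported again.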

Compound 3, half-maximal inhibitory concentration: 36800 nM
Estimate against measurement, compound 3: 3.3-fold (0.51 log units) above, and the stated range ends above it.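

In this assay, the group on the saturated chain carbon bound to an aromatic nitrogen now moves the number beyond the scatter, with an at least 3.4-fold lower number from compound 2 to compound 3 (0.54 log units; beyond the scatter), which the earlier step within the scatter could not show. The 4-methoxybenzyl group also separates from the 4-methylphenyl group on the aromatic nitrogen, with a 3.1-fold lower number from compound 1 to compound 3 (0.49 log units; beyond the scatter). Compound 2 has only a limit of the assay, so the step that starts from it gives a floor and not a full size: the limit of > 128000 nM in this assay, at which 1 of the 3 values shown sits.

The compounds shown leave open whether the lower number of compound 3 goes with the methoxy group or with the loss of the two chlorine atoms, and, against compound 1, with the added chain carbon or with the exchange of methyl for methoxy. A 4-methylbenzyl, a 4-chlorobenzyl or an unsubstituted benzyl group in the same place could separate these readings.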